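The source may hold more compounds than are shown below. What is called first, only, known or untested is meant among the compounds shown, and "the series" means these compounds.

Measured compounds:
compound 1 `CC(C)Oc1cc(-c2cncc(-c3cnn(C(C)C)c3)c2)ccc1C(N)=O` gives 85 nM in an assay on cells for inhibition of MAP kinase-interacting serine/threonine-protein kinase 1 (Homo sapiens), read by mobility shift assay, with stated times of 10 min and 60 min, in the presence of a further agent that is not named here; a lower number here means a stronger inhibitor, a higher number a weaker inhibitor;
compound 3 `CC(C)Oc1cc(-c2cncc(-c3cnn(C4CCOC4)c3)c2)ccc1C(N)=O` gives 120 nM in this assay;
compound 2 `NC(=O)c1ccc(-c2cccnc2)cc1OC1CCC1` gives 1900 nM in this assay.

Compound 1 holds the lowest number of the three. Compound 3 lies within the scatter of it, while compound 2, which carries no group at all on that position of the ring, sits far higher. Compound 4 `CC(C)Oc1cc(-c2cncc(-c3nn[nH]n3)c2)ccc1C(N)=O` differs from compound 1 by 2H-tetrazol-5-yl in place of 1-isopropyl-1H-pyrazol-4-yl on an aromatic carbon. Within the data shown here, the only measured step at that place, a 1.4-fold higher number from compound 1 to compound 3 (0.15 log units; within the scatter), kept the pyrazole and changed only its substituent; no measured pair exchanges the whole ring. So the step is expected to be larger and upward: the estimate for compound 4 is 400 nM (range 80 nM to 2000 nM), a step of a 4.7-fold higher number from compound 1 to compound 4 (0.67 log units; beyond the scatter).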

Compound 4, half-maximal inhibitory concentration: 310 nM
Beside the measured number, compound 4's estimate is 1.3-fold (0.11 log units) above it; the measured number falls inside the stated range.
By their numbers in this assay, from the lowest: compounds 1 and 3 (each within the scatter of the next); then compound 4; then compound 2.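

Exchanging the whole ring at this position gives a 3.6-fold higher number from compound 1 to compound 4 (0.56 log units; beyond the scatter) in this assay and so, unlike the change of substituent on the pyrazole, moves the number beyond the scatter. The step is modest, so the 1-isopropyl-1H-pyrazol-4-yl group is not needed for inhibition at this level, and the smaller 2H-tetrazol-5-yl, which brings a hydrogen-bond donor, is accepted on this aromatic carbon. Nothing measured here explains the step. As far as these compounds go, whether an isopropyl group on the tetrazole would bring the number back remains open. So does the effect of a carboxylic acid or an aminomethyl group at this place.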